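The compounds below may be only part of what the source reports. "The series", "measured", "known", "first", "only" and "open" are said of these compounds alone.

Measured so far in an ADME assay on NCM460 cells (Homo sapiens) for cytotoxicity, read by MTT assay, with a stated time of 24 h; a lower number here means that less compound is tolerated, a higher number that more compound is tolerated:
compound 1 `CC1(C)[C@H]2CC[C@]1(C)N(Cc1cn(-c3ccc(C#N)cc3)nn1)C(=O)C2` gives 8140 nM
compound 2 `CC1(C)[C@H]2CC[C@]1(C)N(Cc1cn(-c3ccccc3C#N)nn1)C(=O)C2` gives 37500 nM

Among the compounds with values here, compound 2 holds the highest of the two numbers; the only step in the set, a 4.6-fold higher number from compound 1 to compound 2 (0.66 log units; beyond the scatter), separates it from compound 1, so compound 2 is the better tolerated of the two.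

Compound 3 `CC1(C)[C@H]2CC[C@]1(C)N(Cc1cn(-c3ccccc3F)nn1)C(=O)C2` differs from compound 2 in one place: fluoro in place of cyano on an aromatic carbon. Within the data shown here, no measured pair exchanges the cyano for any other group; the single step, a 4.6-fold higher number from compound 1 to compound 2 (0.66 log units; beyond the scatter), puts 2-cyanophenyl in place of 4-cyanophenyl on an aromatic nitrogen and says nothing about a fluoro. Among the measured compounds shown here, with no step that bears on this change, the expectation is a number close to that of compound 2, with a wide allowance on either side. Compound 3 is therefore estimated at 30000 nM, between 12000 nM and 80000 nM. For compound 3 this means an expected 1.3-fold lower number from compound 2 to compound 3 (0.10 log units; within the scatter), not beyond the scatter.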

Compound 3, half-maximal cytotoxic concentration: 5260 nM
Estimate against measurement, compound 3: 5.7-fold (0.76 log units) above, outside the stated range (below it).
By their numbers in this assay, from the lowest: compounds 3 and 1 (each within the scatter of the next); then compound 2.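

Exchanging the nitrile for fluoro on this ring carbon gives a 7.1-fold lower number from compound 2 to compound 3 (0.85 log units; beyond the scatter) in this assay, so the high number of compound 2 does not follow from having a substituent at this ring position alone; here it depends on which group sits there. The step of a 1.5-fold lower number from compound 1 to compound 3 (0.19 log units; within the scatter) leaves the 2-fluorophenyl and 4-cyanophenyl compounds unseparated, and compound 2 alone stands apart from the other two. Nothing available on these compounds accounts for this difference between nitrile and fluoro.

Going by these compounds, it remains open whether the nitrile is a special case or whether other groups at this position also give high numbers, such as a methoxy, an amine or a carboxylic acid. The unsubstituted phenyl and the 4-fluorophenyl would show how much either group contributes on its own.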